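The source may report more compounds than this note shows. Statements on the series, on what has been measured and on what is new or still open speak of the compounds shown alone.

Measured so far in this series:

- compound 1, `CC1=CC[C@@H]([C@@](C)(O)CCCC(C)(C)NC(=S)N/N=C\c2ccccc2[N+](=O)[O-])CC1`: in a functional assay on NCI-H460 cells (Homo sapiens) for cytotoxicity, read by sulforhodamine B assay (a higher number here means that more compound is tolerated, a lower number that less compound is tolerated), compound 1 reaches only the limit > 100000 nM.
- compound 2, `CC1=CC[C@@H]([C@@](C)(O)CCCC(C)(C)NC(=S)N/N=C\c2cccc([N+](=O)[O-])c2)CC1`: in this assay compound 2 reaches only the limit > 100000 nM.

Among the compounds with values here, compound 2 therefore stands nowhere on a readable scale: its value is a limit, and the one other value shown is also a limit, so both sit at the limit of > 100000 nM in this assay, at which 2 of the 2 values shown sit. Within the data shown here, the single measured step, a step that the two limits leave unreadable from compound 1 to compound 2, cannot be sized, since both of its ends are limits.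

Compound 3, `CC1=CC[C@@H]([C@@](C)(O)CCCC(C)(C)NC(=S)N/N=C\c2ccccc2Cl)CC1`, differs from compound 2 by 2-chlorophenyl in place of 3-nitrophenyl on a carbon with a double bond to nitrogen. Among the measured compounds shown here, the only measured step that bears on this change is the one from compound 1 to compound 2, and it gives no readable size in either direction. For the measured compounds named here, no step has yet moved a value off the limit, so nothing here points to a change beyond the scatter.

For compound 3 the estimate is 100000 nM, with a range from 30000 nM to 300000 nM, which corresponds to an expected step of a number no higher from compound 2 to compound 3 (the limit leaves the size open); the likeliest outcome is that compound 3 again reports only a limit.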

Compound 3, concentration lethal to 50% of the cells: > 100000 nM
Compound 3: only a limit was reported (the forecaster's own chance of this, stated with the estimate: 70%); the middle value lies on the limit itself.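

No new step can be read among compound 1, compound 2 and compound 3, since all three report only a limit in this assay: the limit of > 100000 nM in this assay, at which 3 of the 3 values shown sit.

The compounds shown leave open where the true value of each lies past that limit, and whether exchanging 2-nitrophenyl, 3-nitrophenyl and 2-chlorophenyl changes the read-out at all.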